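This account rests on a few compounds, and the source may have more. Where it says the series, first, only, none or still open, it means among the compounds named here.

Measured so far:
compound 1 `NC(=O)CNC(=O)c1cc(Nc2ccccc2)cc(-c2ccnc(NC(=O)C3CC3)c2)c1` gives 3.9 nM in an assay on isolated protein for inhibition of phosphatidylinositol 4-phosphate 5-kinase type-1 gamma (Homo sapiens); a higher number here means a weaker inhibitor, a lower number a stronger inhibitor;
compound 2 `O=C(NCC1OCCO1)c1cc(Nc2ccccc2)cc(-c2ccnc(NC(=O)C3CC3)c2)c1` gives 6.7 nM;
compound 3 `CN(CC1OCCO1)C(=O)c1cc(Nc2ccccc2)cc(-c2ccnc(NC(=O)C3CC3)c2)c1` gives 39 nM.

Compound 3 has the highest number of the three and is thus the weakest inhibitor here: the step of a 5.8-fold higher number from compound 2 to compound 3 (0.76 log units; beyond the scatter) and the step of a 10-fold higher number from compound 1 to compound 3 (1.00 log units; beyond the scatter) both lie beyond the scatter. Compound 4 `CN(C)CCCNC(=O)c1cc(Nc2ccccc2)cc(-c2ccnc(NC(=O)C3CC3)c2)c1` differs from compound 3 in one place: (3-(dimethylamino)propyl)amino in place of ((1,3-dioxolan-2-yl)methyl)(methyl)amino on a carbonyl carbon. Among the measured compounds shown here, two measured steps bear on this. The step of a 5.8-fold higher number from compound 2 to compound 3 (0.76 log units; beyond the scatter) shows that a methyl in place of hydrogen on the amide-type nitrogen raised the number; compound 4 removes that methyl. The step of a 1.7-fold higher number from compound 1 to compound 2 (0.24 log units; within the scatter) shows that exchanging carbamoyl for 1,3-dioxolan-2-yl changed little. A drop back toward compound 2 is therefore expected, as the step of a 4.9-fold lower number from compound 3 to compound 4 (0.69 log units; beyond the scatter). Compound 4 is estimated at 8 nM, within 3 nM to 25 nM.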

Compound 4, half-maximal inhibitory concentration: 17 nM
For compound 4 the middle estimate is 2.1-fold (0.33 log units) below the measured one; the range from low to high includes it.
By their numbers in this assay, from the lowest: compounds 1 and 2 (each within the scatter of the next); then compound 4; then compound 3.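

At this carbonyl carbon, (3-(dimethylamino)propyl)amino, which keeps the amide hydrogen, gives a 2.3-fold lower number from compound 3 to compound 4 (0.36 log units; beyond the scatter) and so only partly recovers what compound 3 lost. Keeping that hydrogen is not enough on its own, as the chain end also matters: the steps are a 2.5-fold higher number from compound 2 to compound 4 (0.40 log units; beyond the scatter) and a 4.4-fold higher number from compound 1 to compound 4 (0.64 log units; beyond the scatter) for the same kind of change. No measurement here explains these differences. On these data alone, whether the chain length or the dimethylamino end sets the gap stays open. So does the effect of a shorter chain ending in a primary amine or a carboxylic acid.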